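Hydroxy to Amino: Two Matched Pairs Compared

The compounds below may be only part of what the source reports. "The series", "measured", "known", "first", "only" and "open" are said of these compounds alone.

Compound 1 `Oc1ccc(/C=C/c2ccccc2O)cc1` and compound 2 `Oc1cccc(/C=C/c2cccc(O)c2)c1` are built from the same atoms joined differently; the difference between the two cores is not broken down here. In a functional assay on HT-29 cells (Homo sapiens) for inhibition, read by MTT assay, with a stated time of 2 days (a lower number here means a stronger inhibitor, a higher number a weaker inhibitor), compound 1 gives 22 ug/mL and compound 2 gives 25.9 ug/mL, two numbers that lie within the usual scatter of each other. Compound 3 `Nc1ccccc1/C=C/c1ccc(O)cc1` reaches only the limit of the assay, > 100 ug/mL. Compound 3 differs from compound 1 by amino in place of hydroxy on an aromatic carbon. That change brought an at least 4.5-fold higher number from compound 1 to compound 3 (0.65 log units; beyond the scatter), a step whose size is known only as a bound because of the limit of > 100 ug/mL in this assay, at which 1 of the 3 values shown sits. Compound 4 `Nc1cccc(/C=C/c2cccc(O)c2)c1` has not yet been measured. It differs from compound 2 by amino in place of hydroxy on an aromatic carbon, the same kind of change as before, here meta to a group of 9 heavy atoms where the earlier one was ortho to a group of 9 heavy atoms. In this assay compound 4 is expected to show a 4.2-fold higher number from compound 2 to compound 4 (0.63 log units; beyond the scatter), an expectation resting on the loss seen for compound 3 in an at least 4.5-fold higher number from compound 1 to compound 3 (0.65 log units; beyond the scatter). Compound 4 is therefore estimated at 110 ug/mL, with a range from 45 ug/mL to 300 ug/mL, and a limit rather than a number is the likelier outcome.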

Compound 4, half-maximal inhibitory concentration: 43 ug/mL
Compound 4: middle estimate off by 2.6-fold (0.41 log units), on the high side, and the stated range ends above it.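

In this assay, amino in place of hydroxy on an aromatic carbon, here meta to a group of 9 heavy atoms, brought a 1.7-fold higher number from compound 2 to compound 4 (0.22 log units; within the scatter), so on this core the change leaves no difference that can be told from the scatter. The same change thus does not carry over at one size from the core of compound 1 to the core of compound 2: the same change on two cores in this assay, an at least 4.5-fold higher number (0.65 log units; beyond the scatter) from compound 1 to compound 3 and a 1.7-fold higher number (0.22 log units; within the scatter) from compound 2 to compound 4, at least 2.7-fold (0.43 log units) apart, beyond the scatter of two such steps. These two pairs do not show whether the core or the place of the amino group sets the size of the step, and the earlier step is known only as a bound: the limit of > 100 ug/mL in this assay, at which 1 of the 4 values shown sits.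

The compounds shown leave open how other groups at these places would compare with hydroxy and amino on either core, for instance a methoxy group, a dimethylamino group or a carboxylic acid. They also leave open whether the amino group would give a step like either of these two on a third core.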